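From 2-iodophenyl to 3-iodophenyl: working notes

The source may report more compounds than this note shows. Statements on the series, on what has been measured and on what is new or still open speak of the compounds shown alone.

In a functional assay on CRL2813 cells (Homo sapiens) for cytotoxicity, read by sulforhodamine B assay, with a stated time of 5 days (on this read-out higher numbers stand for weaker inhibition and lower numbers for stronger inhibition), compound 2 (`O=C(Nc1ccccc1I)N[C@H]1CC[C@H](Oc2ccc(F)cc2)CC1`) gives > 20000 nM, which is a limit and not a number. Compound 1 (`CSc1ccccc1NC(=O)N[C@H]1CC[C@H](Oc2ccc(F)cc2)CC1`) gives > 20000 nM in this assay, which is also a limit. The position of compound 2 therefore cannot be read beyond (the limit of > 20000 nM in this assay, at which 2 of the 2 values shown sit). For the measured compounds named here, the one measured step, a step that the two limits leave unreadable from compound 1 to compound 2, has no readable size and concerns a different change. Compound 3 (`O=C(Nc1cccc(I)c1)N[C@H]1CC[C@H](Oc2ccc(F)cc2)CC1`) carries 3-iodophenyl in place of 2-iodophenyl on an amide-type nitrogen. Going by the values given here, no measured step tests this change, and the only guide is that compound 2 gives > 20000 nM. No step beyond the scatter is therefore expected in this assay. The estimated step is a number no higher from compound 2 to compound 3 (the limit leaves the size open). Compound 3 is expected near 20000 nM, with an estimated range of 10000 nM to 40000 nM, and a reading at the limit is likely.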

Compound 3, half-maximal inhibitory concentration: 5200 nM
Estimate against measurement, compound 3: 3.8-fold (0.59 log units) above; measured number below the stated range.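

In this assay, 3-iodophenyl in place of 2-iodophenyl on an amide-type nitrogen gives an at least 3.8-fold lower number from compound 2 to compound 3 (0.58 log units; beyond the scatter), so the iodine-bearing ring is sensitive at this place even though the two groups hold the same atoms, joined differently. The same place also gives an at least 3.8-fold lower number from compound 1 to compound 3 (0.58 log units; beyond the scatter) with 3-iodophenyl in place of 2-(methylsulfanyl)phenyl, while the step between the two compounds held at the limit cannot be read. Compound 3 is the only compound shown with a number rather than a limit: the limit of > 20000 nM in this assay, at which 2 of the 3 values shown sit.

Going by these compounds, the full size of both readable steps stays open, since each starts from a limit. Also open, on these data alone, is whether the drop in the number belongs to iodine itself or would also appear with 3-(methylsulfanyl)phenyl, 3-chlorophenyl or 4-iodophenyl at this nitrogen.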